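The source may report more compounds than this note shows. Statements on the series, on what has been measured and on what is new or still open speak of the compounds shown alone.

Compound 1 `CC1=CC(C)(C)N(Cc2ccc(C(F)(F)F)cc2)c2ccc(OCc3ccc(C(F)(F)F)cc3)cc21`: > 180000 nM
Compound 2 `CC(=O)Oc1ccc2c(c1)C(C)=CC(C)(C)N2Cc1ccccc1`: 24000 nM

The test here is an ADME assay on L6 cells (Rattus norvegicus) for cytotoxicity, read by resazurin assay, with a stated time of 70 h; on this read-out higher numbers stand for weaker inhibition and lower numbers for stronger inhibition. Compound 1 gives > 180000 nM, which is a limit of the assay and not a number. For the measured compounds named here, compound 2, at 24000 nM, therefore holds the only actual number so far.

Compound 3 `CC(=O)Oc1ccc2c(c1)C(C)=CC(C)(C)N2Cc1cccc(Cl)c1` keeps the shared core of compound 2 and changes in one place, where phenyl becomes 3-chlorophenyl: chloro in place of hydrogen on an aromatic carbon. The benzyl group thus becomes 3-chlorobenzyl. Going by the values given here, no pair of measured compounds differs in a single place, so nothing yet shows how large such a change can be in this assay. A single added chloro is expected to give a small move toward lower numbers, perhaps none beyond the scatter. The expected change is a 1.3-fold lower number from compound 2 to compound 3 (0.12 log units; within the scatter). For compound 3 the estimated value is 18000 nM, with an expected range from 7000 nM to 45000 nM.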

Compound 3, half-maximal inhibitory concentration: 29000 nM
The estimate for compound 3 lay 1.6-fold (0.21 log units) below the measured number, within the range that was stated.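

For the compounds shown here, this is the first comparison of two compounds that differ in only one place, and in this assay it gives a clear reading (a 1.2-fold higher number from compound 2 to compound 3 (0.08 log units; within the scatter)). Placing a chloro on the aromatic carbon of the benzyl group, turning it into 3-chlorobenzyl, therefore leaves compound 2 and compound 3 indistinguishable on this read-out, and the one added heavy atom is tolerated at this position without a detectable shift. Compound 1 is the only compound shown with a limit and not a number, and it differs from the others in more than one place, so it adds nothing to this comparison: the limit of > 180000 nM in this assay, at which 1 of the 3 values shown sits.

A single step at a single position cannot show whether a larger group would behave the same way. A methoxy group or an amine on this ring could still move the number beyond the scatter, as could a chloro placed elsewhere on it.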